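Adding a methoxy to the aniline ring of compound 1

A few compounds are considered here, and "the series" means these few. Any claim that something is new, unique, unknown or untested is made for them only; others in the source may bear on it.

Compound 1, whose structure is `COc1cccc(C(=O)c2sc(Nc3ccccc3)nc2N)c1`, was tested in a functional assay on HeLa cells (Homo sapiens) for antiproliferative activity, read by cell counting, with a stated time of 2 days (a lower number here means a stronger inhibitor, a higher number a weaker inhibitor), and gives 1700 nM. Of the two numbers measured, that is the highest; its nearest neighbour is compound 2, `COc1cc(C(=O)c2sc(Nc3ccccc3)nc2N)cc(OC)c1OC`, which in this assay gives 14 nM, a step beyond the usual scatter. Compound 3, `Nc1nc(Nc2ccc(Cl)cc2)sc1C(=O)c1ccccc1`, reaches only a limit of the assay: in this assay compound 3 gives > 10000 nM. The unmeasured compound 4 is `COc1ccc(Nc2nc(N)c(C(=O)c3cccc(OC)c3)s2)cc1`. It differs from compound 1 by methoxy in place of hydrogen on an aromatic carbon. Going by the values given here, no measured pair shows this change, so the expected step from compound 1 to compound 4 is small, perhaps slightly weakening, and not clearly beyond the scatter: the estimate is a 1.5-fold higher number from compound 1 to compound 4 (0.17 log units; within the scatter). Compound 4 is therefore expected to give about 2500 nM, between 800 nM and 8000 nM.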

Compound 4, half-maximal inhibitory concentration: 37 nM
Compound 4: the middle estimate sits 68-fold (1.83 log units) above what was measured, and the stated range ends above it.
By their numbers in this assay, from the lowest: compound 2; then compound 4; then compound 1. At a limit, above all of these: compound 3.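

Going from phenyl to 4-methoxyphenyl gives a 46-fold lower number from compound 1 to compound 4 (1.66 log units; beyond the scatter) in this assay, so this place on the aniline ring, para to a large group, strongly affects the read-out. Going by these compounds alone, no earlier pair isolated this place, and this step is the first direct reading of it. Nothing shown here explains why one methoxy changes the number so much.

Going by these compounds, it remains open whether the gain is particular to methoxy or would also come with an ethoxy or an amine in the same place. On these data alone, whether the same change would add anything to compound 2 also remains open.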